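The compounds below may be only part of what the source reports. "The series", "measured", "known", "first", "only" and "open" are said of these compounds alone.

Working notes on the series. In a functional assay on MCF7 cells (Homo sapiens) for antiproliferative activity, read by MTT assay, with a stated time of 48 h (a higher number here means a weaker inhibitor, a lower number a stronger inhibitor), compound 1 `O=C(Nc1cccc(/C=C/C(=O)c2nc3ccccc3[nH]2)c1)c1cccc(Cl)c1` gives 7840 nM and compound 2 `Cc1ccc(C(=O)Nc2cccc(/C=C/C(=O)c3nc4ccccc4[nH]3)c2)cc1` gives 9690 nM. Among the measured compounds shown here, compound 2 thus sits within the scatter of compound 1, the only other measured member, and the two cannot be separated on this assay. For the measured compounds named here, the single measured step, a 1.2-fold higher number from compound 1 to compound 2 (0.09 log units; within the scatter), exchanges one aryl group on the amide carbonyl for another without leaving the scatter. Compound 3 `COc1cccc(C(=O)Nc2cccc(/C=C/C(=O)c3nc4ccccc4[nH]3)c2)c1` is not yet measured; relative to compound 2 it carries 3-methoxyphenyl in place of 4-methylphenyl on a carbonyl carbon. Going by the values given here, the only measured step bearing on this change is that aryl exchange between compound 1 and compound 2, which was within the scatter, so for this assay no step beyond the scatter is expected from compound 2 to compound 3: a 1.1-fold lower number from compound 2 to compound 3 (0.03 log units; within the scatter). Compound 3 is estimated at 9000 nM, with a range of 4000 nM to 20000 nM.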

Compound 3, half-maximal inhibitory concentration: 17800 nM
Estimate against measurement, compound 3: 2.0-fold (0.30 log units) below; the measured number falls inside the stated range.
By their numbers in this assay, from the lowest: compounds 1, 2 and 3 (each within the scatter of the next, the first and the last beyond it).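

In this assay the exchange of aryl groups on the amide carbonyl stays within the scatter in one case, a 1.8-fold higher number from compound 2 to compound 3 (0.26 log units; within the scatter), but the series now holds its first step beyond the scatter, modest in size: a 2.3-fold higher number from compound 1 to compound 3 (0.36 log units; beyond the scatter). Methoxy in place of chloro on an aromatic carbon is therefore a change that this position can register, while compound 2 cannot be separated from either of the other two compounds. No measurement bears on what lies behind this difference.

Open, from the compounds shown here alone, is whether an amine or a carboxylic acid on this aryl ring would move the number further than methoxy or chloro does. Also open, going by these compounds, is whether a change in the shared core would leave this small difference between compound 1 and compound 3 intact.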